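Bromobenzyl to Cyanobenzyl on a Shared Hydroxypiperidine Core

This account rests on a few compounds, and the source may have more. Where it says the series, first, only, none or still open, it means among the compounds named here.

Within the data shown here, compound 2 `O=c1c2cnn(-c3ccc(F)cc3)c2ncn1CC1(O)CCN(Cc2ccc(Br)cc2)CC1` is the only member of this small group with a number attached to it. In an assay on Sf21 cells for inhibition of ubiquitin carboxyl-terminal hydrolase 7 (Homo sapiens), read by spectrophotometry, with stated times of 30 min and 2 h (a higher number here means a weaker inhibitor, a lower number a stronger inhibitor), compound 2 gives 6700 nM. Compound 1 `O=c1c2cnn(-c3ccc(F)cc3)c2ncn1CC1(O)CCN(Cc2ccncc2)CC1` was also prepared, but in this assay compound 1 gives "not determined" (no result reported), so compound 2 stands alone on the numbers shown, with nothing alongside it to call it strong or weak. Compound 3 `N#Cc1ccccc1CN1CCC(O)(Cn2cnc3c(cnn3-c3ccc(F)cc3)c2=O)CC1` has not yet been measured. It differs from compound 2 in one place: 2-cyanophenyl in place of 4-bromophenyl on a saturated chain carbon bound to an amine nitrogen in a ring. Among the measured compounds shown here, no measured pair in this set shows what such a swap does, so the size of the step cannot be read off any known pair. The estimate therefore means a step of a 1.2-fold higher number from compound 2 to compound 3 (0.08 log units; within the scatter), expected to fall within the scatter and in no fixed direction. Compound 3 is expected to give about 8000 nM in this assay, with a range from 2500 nM to 25000 nM.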

Compound 3, half-maximal inhibitory concentration: 8100 nM
The estimate for compound 3 lay 1.0-fold (0.01 log units) below the measured number; the range from low to high includes it.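

Among these compounds, the swap of 4-bromophenyl for 2-cyanophenyl on a saturated chain carbon bound to an amine nitrogen in a ring gives the first step that can be read in this set: in this assay it is a 1.2-fold higher number from compound 2 to compound 3 (0.08 log units; within the scatter) and so the two compounds cannot be told apart. This position therefore accepts two different substituted phenyl groups, one carrying bromine and the other a nitrile with its one hydrogen-bond acceptor, with no change beyond the scatter, though both values come from a single pair and say nothing yet about other groups at this place. Since the group and its place on the phenyl ring change together, and nothing measured offers a reason for the result, the step cannot be divided between the two or explained.

In this assay compound 1 gives "not determined" (no result reported) and so any step to it cannot be read, which leaves open how the 4-pyridyl-type ring of that compound compares with either phenyl group. Also open, going by these compounds, is whether 4-cyanophenyl, 2-bromophenyl, a carboxylic acid or a longer chain at this place would move the value beyond the scatter.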